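Swapping the aryl group on the benzyl thioether of compound 2

The compounds below may be only part of what the source reports. "The series", "measured", "known", "first", "only" and "open" are said of these compounds alone.

Compound 2 `O=[N+]([O-])c1cccc(CSc2nc3cc(Cl)c(Cl)cc3n2C2O[C@H](CO)[C@@H](O)[C@H]2O)c1` is one of two measured members of this series. In a functional assay on KB cells (Homo sapiens) for inhibition (on this read-out higher numbers stand for weaker inhibition and lower numbers for stronger inhibition), compound 2 gives 25000 nM, and the companion compound 1 `OC[C@H]1OC(n2c(SCc3ccccc3Cl)nc3cc(Cl)c(Cl)cc32)[C@H](O)[C@@H]1O` gives 30000 nM in this assay, so the two numbers lie within the usual scatter of each other. Going by the values given here, the single measured step between them, a 1.2-fold lower number from compound 1 to compound 2 (0.08 log units; within the scatter), shows that exchanging one aryl group for another at this position left the read-out essentially unchanged.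

Compound 3 `CC(C)(C)c1ccc(CSc2nc3cc(Cl)c(Cl)cc3n2C2O[C@H](CO)[C@@H](O)[C@H]2O)cc1` has not yet been measured. It differs from compound 2 in one place: 4-(tert-butyl)phenyl in place of 3-nitrophenyl on a saturated chain carbon bound to a sulfur. Among the compounds with values here, the only step that bears on this change is the aryl exchange from compound 1 to compound 2, which stayed within the scatter, and it gives no reason to expect a shift beyond the scatter in either direction for compound 3 in this assay.

Compound 3 is therefore estimated at 25000 nM in this assay, with a range from 8000 nM to 80000 nM, which corresponds to an expected step of no change at the digits printed from compound 2 to compound 3 (within the scatter).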

Compound 3, half-maximal inhibitory concentration: 50000 nM
Compound 3: middle estimate off by 2.0-fold (0.30 log units), on the low side; measured number inside the range.
By their numbers in this assay, from the lowest: compounds 2, 1 and 3 (each within the scatter of the next).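

In this assay the read-out shows a 2.0-fold higher number from compound 2 to compound 3 (0.30 log units; within the scatter) and also a 1.7-fold higher number from compound 1 to compound 3 (0.22 log units; within the scatter), so a third aryl group on the saturated chain carbon bound to a sulfur stays within the scatter of both earlier ones. Going by these compounds alone, the earlier pair compared only two substituted phenyl groups, whereas this change replaces 3-nitrophenyl, with 2 hydrogen-bond acceptors and nitrogen and oxygen among its heavy atoms, with 4-(tert-butyl)phenyl, with 10 heavy atoms that are all carbon and 0 hydrogen-bond acceptors, and the number still does not leave the scatter. No measured information is available to explain this insensitivity of the read-out.

Going by these compounds, all three compounds carry a single substituted phenyl ring on this carbon, so it remains open whether a carboxylic acid or an amine on that ring, or a plain alkyl chain in place of the ring, would move the number beyond the scatter. Also open, on these data alone, is whether a longer chain between the sulfur and the ring would do so, and whether any group at this position can shift the read-out at all.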